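Replacing trifluoromethyl with a methoxyphenoxymethyl arm

A few compounds are considered here, and "the series" means these few. Any claim that something is new, unique, unknown or untested is made for them only; others in the source may bear on it.

Compound 1 `CC(C)(NC(=O)c1ccc([N+](=O)[O-])o1)c1ccccc1` in an ADME assay on Vero cells (Chlorocebus sabaeus) for cytotoxicity, read by MTT assay, with a stated time of 48 h (on this read-out higher numbers stand for lower toxicity in this test and lower numbers for higher toxicity in this test), gives > 180000 nM, which is a limit of the assay rather than a number. Compound 2 `CC(C)(NC(=O)c1ccc([N+](=O)[O-])o1)c1ccc(C#N)cc1` in this assay gives 83000 nM. Compound 3 `CC(C)(NC(=O)c1ccc([N+](=O)[O-])o1)c1ccc(C(F)(F)F)cc1` in this assay gives > 150000 nM, again a limit of the assay and not a number.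

Compound 3 thus stands at the top of what this assay resolved, as does compound 1; only compound 2 returned a number. The steps among the three are accordingly hard to read: a step that the two limits leave unreadable from compound 1 to compound 3, while an at least 1.8-fold higher number from compound 2 to compound 3 (0.25 log units; that floor lies within the scatter), and only an at least 2.1-fold lower number from compound 1 to compound 2 (0.33 log units; beyond the scatter). The two limits are the reason the step to compound 3 cannot be sized; see the limit of > 150000 nM in this assay, at which 1 of the 3 values shown sits, and (the limit of > 180000 nM in this assay, at which 1 of the 3 values shown sits).

Compound 4 `COc1ccc(OCc2ccc(C(C)(C)NC(=O)c3ccc([N+](=O)[O-])o3)cc2)cc1` differs from compound 3 in one place: (4-methoxyphenoxy)methyl in place of trifluoromethyl on an aromatic carbon. Among the measured compounds shown here, none of the measured steps involves a group of this kind or size, so the expectation rests on compound 3 sitting at a limit and on the small spread of the three values. A modest fall is expected, an at least 1.8-fold lower number from compound 3 to compound 4 (0.27 log units; that floor lies within the scatter), with a fair chance that compound 4 again returns only a limit. Compound 4 is therefore estimated at 80000 nM, between 25000 nM and 200000 nM.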

Compound 4, half-maximal cytotoxic concentration: > 120000 nM
Compound 4 gave a limit, no number; the forecaster's own chance of this, stated with the estimate: 35%; middle value at least 1.5-fold (0.17 log units) from the limit.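

In this assay compound 4 returns only a limit of the assay, not a number, so even the (4-methoxyphenoxy)methyl arm, far larger than trifluoromethyl and bringing a second aromatic ring, gives no readable value at this position: the limit of > 120000 nM in this assay, at which 1 of the 4 values shown sits. The steps from compound 1 and from compound 3 to compound 4 cannot be read. Among the compounds shown here, the one readable comparison is with the nitrile of compound 2, which gives an at least 1.4-fold higher number from compound 2 to compound 4 (0.16 log units; that floor lies within the scatter), and since that floor stays within the scatter, it does not by itself separate the two compounds.

As far as these compounds go, what remains open is how far the true values of compound 1, compound 3 and compound 4 lie past their limits, and so whether these three compounds differ at all in this test. Also open, from the compounds shown here alone, is what an amine, a carboxylic acid or a longer carbon chain at this same position would give in this assay, and whether any of them, like the nitrile of compound 2, would return a number rather than a limit.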